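Swapping a Tert-butyl for a Benzyl on a Carbamate

The compounds below may be only part of what the source reports. "The series", "measured", "known", "first", "only" and "open" are said of these compounds alone.

Compound 1 `C/C(=C\COC(=O)NC(C)(C)C)C1=CC(=O)C(C)(C)O1`: in a functional assay on FM3A cells (Mus musculus) for inhibition (on this read-out lower numbers stand for stronger inhibition and higher numbers for weaker inhibition), compound 1 gives 7.1 ug/mL
Compound 2 `C/C(=C\C=C/C1CCCCC1)C1=CC(=O)C(C)(C)O1`: in this assay compound 2 gives 10.8 ug/mL

Only these two compounds have been measured. Compound 1 and compound 2 have numbers that lie within the usual scatter of each other, so neither can be called the stronger inhibitor on this evidence; compound 1 simply sits at one end of a pair that is, for practical purposes, level.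

Compound 3 `C/C(=C\COC(=O)NCc1ccccc1)C1=CC(=O)C(C)(C)O1` shares the core of compound 1 and differs from it in one spot: benzyl in place of tert-butyl on an amide-type nitrogen. Going by the values given here, nothing among the measured compounds shows what such a swap does in this assay, so there is no measured step to lean on. With a change confined to the tail of the carbamate, the step of a 1.0-fold lower number from compound 1 to compound 3 (0.01 log units; within the scatter) is expected to be small, with no clear direction, and most likely to stay within the scatter. Compound 3 is therefore estimated at 7 ug/mL, with a range from 3 ug/mL to 16 ug/mL.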

Compound 3, half-maximal inhibitory concentration: 8.1 ug/mL
Estimate against measurement, compound 3: 1.2-fold (0.06 log units) below; the range from low to high includes it.
By their numbers in this assay, from the lowest: compounds 1, 3 and 2 (each within the scatter of the next).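

In this assay, putting benzyl in place of tert-butyl on the amide-type nitrogen gives a 1.1-fold higher number from compound 1 to compound 3 (0.06 log units; within the scatter) and leaves compound 1 and compound 3 impossible to tell apart. Going by these compounds alone, this is the first measured step at this position, and it shows that a tail carrying a six-membered aromatic ring can stand there in place of a tail with no ring and keep the number level with that of compound 1. No measurement at hand says why these two groups read alike.

Going by these compounds, both tails are built of carbon only, so it remains open how this assay would respond to an amine or a carboxylic acid at the end of the tail. A longer chain between the nitrogen and the benzene ring, or a substituent such as fluorine on that ring, is equally untested among the compounds shown.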